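The source may hold more compounds than are shown below. What is called first, only, known or untested is meant among the compounds shown, and "the series" means these compounds.

Measured compounds:
- compound 1 `CN(C)CCn1cnnc1-c1cc(Oc2ccc(NC(=O)N/N=C/c3ccccc3O[N+](=O)[O-])cc2F)ccn1`: 7150 nM
- compound 2 `COc1cc(/C=N/NC(=O)Nc2ccc(Oc3ccnc(-c4nncn4CCN(C)C)c3)c(F)c2)cc(OC)c1OC`: 22500 nM
- compound 3 `CN(C)CCn1cnnc1-c1cc(Oc2ccc(NC(=O)N/N=C/c3cccc(Br)c3)cc2F)ccn1`: 830 nM

In a functional assay on U-87MG ATCC cells (Homo sapiens) for cytotoxicity, read by MTT assay, with a stated time of 72 h (a lower number here means a stronger inhibitor, a higher number a weaker inhibitor), compound 3 gives the lowest number of the three. The gaps are an 8.6-fold lower number from compound 1 to compound 3 (0.94 log units; beyond the scatter) and a 27-fold lower number from compound 2 to compound 3 (1.43 log units; beyond the scatter); the two weaker compounds themselves are separated by a 3.1-fold higher number from compound 1 to compound 2 (0.50 log units; beyond the scatter). All three differ only in the aryl group on the carbon with a double bond to nitrogen, so the series shows that this group alone can move the number over a wide span.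

Compound 4 `CN(C)CCn1cnnc1-c1cc(Oc2ccc(NC(=O)N/N=C/c3ccc(F)cc3Cl)cc2F)ccn1` keeps that framework and changes the same group: 2-chloro-4-fluorophenyl in place of 3-bromophenyl on a carbon with a double bond to nitrogen. Going by the values given here, no measured step swaps one halogenated phenyl for another; the steps into compound 3 only show that leaving the 3-bromophenyl for a nitrooxy- or trimethoxy-substituted ring raises the number, by a modest to large amount. A halogen-bearing ring is retained here, so the change is expected to be smaller than those, most likely a modest rise, with a 1.8-fold higher number from compound 3 to compound 4 (0.26 log units; within the scatter) as the estimated step. Compound 4 is therefore estimated at 1500 nM, within a range of 400 nM to 5000 nM.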

Compound 4, half-maximal inhibitory concentration: 1210 nM
Beside the measured number, compound 4's estimate is 1.2-fold (0.09 log units) above it; the range from low to high includes it.
By their numbers in this assay, from the lowest: compounds 3 and 4 (each within the scatter of the next); then compound 1; then compound 2.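

In this assay, replacing 3-bromophenyl with 2-chloro-4-fluorophenyl on the carbon with a double bond to nitrogen gives a 1.5-fold higher number from compound 3 to compound 4 (0.16 log units; within the scatter) and so leaves the two halogen-bearing rings unresolved. The new ring still stands clear of the other two aryl groups, with a 19-fold lower number from compound 2 to compound 4 (1.27 log units; beyond the scatter) and a 5.9-fold lower number from compound 1 to compound 4 (0.77 log units; beyond the scatter) in this series, so a different halogenated phenyl ring now shows the same separation from the 3,4,5-trimethoxyphenyl and 2-(nitrooxy)phenyl rings. No evidence is available to account for this separation.

The compounds shown leave open how an unsubstituted phenyl ring, or a phenyl ring carrying an amine or a carboxylic acid, would compare on this carbon. They also do not settle whether the halogens themselves set compound 3 and compound 4 apart from the other two.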